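The source may report more compounds than this note shows. Statements on the series, on what has been measured and on what is new or still open speak of the compounds shown alone.

Of the compounds shown here, three sharing one core have been measured for cytotoxicity. Compound 1 `Nc1nc(Cl)c(-c2nc3ccc(Cl)cc3s2)c(N[C@@H]2C[C@H](CO)[C@@H](O)[C@H]2O)n1` gives in an ADME assay on cells (Homo sapiens) for cytotoxicity, read by polymerase chain reaction, with a stated time of 3 days (on this read-out higher numbers stand for lower toxicity in this test and lower numbers for higher toxicity in this test), a value of 16000 nM. Compound 2 `CN(C)c1ccc2sc(-c3c(Cl)nc(N)nc3N[C@@H]3C[C@H](CO)[C@@H](O)[C@H]3O)nc2c1` gives in this assay a value of 25000 nM. Compound 3 `Cc1nc(NC(C)C)nc(N[C@@H]2C[C@H](CO)[C@@H](O)[C@H]2O)c1-c1nc2ccccc2s1` gives in this assay a value of 13000 nM. The number for compound 3 is the lowest of the three as written, but its distance to compound 1 and its distance to compound 2 both sit within the usual scatter of this read-out, so the three compounds are not separated by this assay.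

Compound 4 `Cc1nc(NCc2cccs2)nc(N[C@@H]2C[C@H](CO)[C@@H](O)[C@H]2O)c1-c1nc2ccccc2s1` has not yet been measured. It differs from compound 3 in one place: (thiophen-2-yl)methyl in place of isopropyl on a nitrogen on an aromatic ring. For the measured compounds named here, none of the measured pairs shows a change of this kind, so there is no step in hand to lean on; the cytotoxic concentrations of compound 1, compound 2 and compound 3 all cluster closely despite their other differences. On that basis the expected step is estimated as a 1.3-fold lower number from compound 3 to compound 4 (0.11 log units; within the scatter), small and not clearly beyond the scatter. Compound 4 is therefore estimated to give in this assay about 10000 nM, with a likely range from 4000 nM to 25000 nM.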

Compound 4, half-maximal cytotoxic concentration: 6000 nM
Estimate against measurement, compound 4: 1.7-fold (0.22 log units) above; low and high end bracket the measured number.
By their numbers in this assay, from the lowest: compound 4; then compounds 3, 1 and 2 (each within the scatter of the next).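

For the compounds shown here, putting (thiophen-2-yl)methyl in place of isopropyl on a nitrogen on an aromatic ring gives in this assay a 2.2-fold lower number from compound 3 to compound 4 (0.34 log units; beyond the scatter) and so provides the one step in this set that can be read, a modest one that lies beyond the usual scatter. The earlier compounds shown here showed only numbers that could not be told apart and no step of any kind, whereas this pair shows that the group on this nitrogen can shift the read-out, with the lower number for compound 4 standing for higher toxicity in this test. The compounds shown offer no evidence that would explain the shift, so it stands as an observation only.

A single pair cannot separate the contribution of the thiophene ring from that of the larger group as a whole, since both enter together in this one change. On these data alone, a benzyl group, a furan-2-ylmethyl group or a cyclopentyl group on the same nitrogen would bear on that question, and whether the step carries over to the chloro-substituted compounds also remains open.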